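Ortho-methyls on the triazole phenyl of a cytotoxic quinoline

The source may report more compounds than this note shows. Statements on the series, on what has been measured and on what is new or still open speak of the compounds shown alone.

Compound 3 `COc1cc2c(Oc3ccc(NC(=O)c4cn(-c5ccccc5)nn4)cc3F)ccnc2cc1OCCCN1CCC(C)CC1` gives 140 nM in a functional assay on A549 cells (Homo sapiens) for cytotoxicity, read by MTT assay, with a stated time of 72 h (a lower number here means a stronger inhibitor, a higher number a weaker inhibitor), the second highest of three numbers. Its nearest neighbour, compound 2 `COc1cc2c(Oc3ccc(NC(=O)c4cn(-c5ccccc5)nn4)cc3F)ccnc2cc1OCCCN1CCCCC1`, gives 130 nM, and a 1.1-fold higher number from compound 2 to compound 3 (0.03 log units; within the scatter). The furthest, compound 1 `COc1cc2c(Oc3ccc(NC(=O)c4cn(-c5ccccc5)nn4)cc3F)ccnc2cc1OCCCN1CCCC1`, gives 360 nM, and a 2.6-fold lower number from compound 1 to compound 3 (0.41 log units; beyond the scatter); likewise a 2.8-fold lower number from compound 1 to compound 2 (0.44 log units; beyond the scatter). Compound 4 `COc1cc2c(Oc3ccc(NC(=O)c4cn(-c5c(C)cccc5C)nn4)cc3F)ccnc2cc1OCCCN1CCC(C)CC1` differs from compound 3 in one place: 2,6-dimethylphenyl in place of phenyl on an aromatic nitrogen. Among the measured compounds shown here, all three measured steps concern the amine at the end of the chain, and none touches the group on the aromatic nitrogen, so no measured step bears on this change. Compound 4 is therefore expected to show a 1.4-fold higher number from compound 3 to compound 4 (0.15 log units; within the scatter) in this assay , with no shift beyond the scatter. Compound 4 is estimated at 200 nM, within 70 nM to 600 nM.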

Compound 4, half-maximal inhibitory concentration: 3340 nM
Compound 4: middle estimate off by 17-fold (1.22 log units), on the low side; the whole stated range lies below it.
By their numbers in this assay, from the lowest: compounds 2 and 3 (each within the scatter of the next); then compound 1; then compound 4.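

At this position the numbers move much further than at the amine end of the chain: replacing phenyl with 2,6-dimethylphenyl on the aromatic nitrogen gives a 24-fold higher number from compound 3 to compound 4 (1.38 log units; beyond the scatter) in this assay. The largest step among the amines, by comparison, is a 2.8-fold lower number from compound 1 to compound 2 (0.44 log units; beyond the scatter). Nothing available explains this loss.

The compounds shown leave open whether a single methyl on the phenyl, or a chlorine or methoxy in its place, would cost as much. They also leave open whether the same change behaves alike with piperidin-1-yl or pyrrolidin-1-yl on the chain.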